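Swapping the Pendant Group on a Lipoxygenase Inhibitor Core

The source may hold more compounds than are shown below. What is called first, only, known or untested is meant among the compounds shown, and "the series" means these compounds.

Measured compounds:
compound 1 `OC1(c2cccc(COc3ccc4c(-c5ccoc5)cc(C5=NCCO5)cc4c3)c2)CCOCC1` gives 70 nM in an assay on isolated protein with Polyunsaturated fatty acid 5-lipoxygenase (Homo sapiens) as the target; on this read-out lower numbers stand for stronger inhibition and higher numbers for weaker inhibition
compound 2 `CC1(C)COC(c2cc(-c3ccoc3)c3ccc(OCc4cccc(C5(O)CCOCC5)c4)cc3c2)=N1` gives 190 nM in this assay
compound 3 `O=C(c1ccccc1)c1cc(-c2ccoc2)c2ccc(OCc3cccc(C4(O)CCOCC4)c3)cc2c1` gives 70 nM in this assay

Compound 3 stands level with compound 1 at the digits shown, and the two together hold the lowest numbers of the three; compound 2 sits furthest away, as the step of a 2.7-fold lower number from compound 2 to compound 3 (0.43 log units; beyond the scatter) records. The step of no change at the digits printed from compound 1 to compound 3 (within the scatter) shows that trading one small five-membered group for the benzoyl group left the number where it was.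

Compound 4 `OC1(c2cccc(COc3ccc4c(-c5ccoc5)cc(Cc5nccs5)cc4c3)c2)CCOCC1` keeps the whole shared core and differs from compound 3 in one place: (1,3-thiazol-2-yl)methyl in place of benzoyl on an aromatic carbon. Among the measured compounds shown here, no measured pair shows this exact swap. What the three measured compounds do show is that three different groups at this same position all land within a narrow band, the widest step being a 2.7-fold higher number from compound 1 to compound 2 (0.43 log units; beyond the scatter). The expectation is therefore a step of comparable size at most, in either direction, most likely within the scatter.

The estimate for compound 4 is 100 nM, with a range from 35 nM to 300 nM, meaning an expected step of a 1.4-fold higher number from compound 3 to compound 4 (0.15 log units; within the scatter).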

Compound 4, half-maximal inhibitory concentration: 140 nM
The estimate for compound 4 lay 1.4-fold (0.15 log units) below the measured number, and the stated range covers the measured number.
By their numbers in this assay, from the lowest: compounds 1, 3, 4 and 2 (each within the scatter of the next, the first and the last beyond it).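

In this assay, (1,3-thiazol-2-yl)methyl puts a five-membered aromatic ring with two hetero atoms on this aromatic carbon, a type of group new among these compounds, and all three new steps stay within the scatter: a 2.0-fold higher number from compound 3 to compound 4 (0.30 log units; within the scatter), a 2.0-fold higher number from compound 1 to compound 4 (0.30 log units; within the scatter) and a 1.4-fold lower number from compound 2 to compound 4 (0.13 log units; within the scatter). The swap from benzoyl also removes the double bond outside aromatic rings and replaces the six-membered aromatic ring of carbon only, yet the read-out does not move beyond the scatter, so at this position the assay does not separate these two quite different groups. Nothing available here explains why these groups read so alike.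

The compounds shown all carry a ring-bearing group at this position, so it remains open whether the same narrow band would hold for an amine, a carboxylic acid or a longer chain there. Also open, from the compounds shown here alone, is whether (1,3-thiazol-2-yl)methyl would read the same way if the furan-3-yl group were replaced by a different group.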